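This account rests on a few compounds, and the source may have more. Where it says the series, first, only, none or still open, it means among the compounds named here.

Measured compounds and their values in a physicochemical assay for solubility, read by mass spectrometry, in phosphate buffer, with a stated time of 24 h, at pH 7.4; a lower number here means a less soluble compound, a higher number a more soluble compound:

compound 1, `O=C(CC1CCN(C(=O)C2CC2)CC1)Nc1ccc(OC(F)(F)F)c(F)c1`, gives 715 ug/mL
compound 2, `O=C(Nc1ccc(C(F)(F)F)c(F)c1)NC1CCN(C(=O)C2CC2)CC1`, gives 0.46 ug/mL
compound 3, `CC(C)C(=O)N1CCC(NC(=O)Nc2ccc(C(F)(F)F)c(F)c2)CC1`, gives 5.9 ug/mL

Compound 1 stands highest of the three in this assay, and both other values lie far beneath it. The difference between the core of compound 1 and the core of compound 2 is not broken down here.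

Within the pair built on the core of compound 2, one change was made: isopropyl in place of cyclopropyl on a carbonyl carbon. That change gave a 13-fold higher number from compound 2 to compound 3 (1.11 log units; beyond the scatter), a large step well outside the usual scatter.

Compound 4, `CC(C)C(=O)N1CCC(CC(=O)Nc2ccc(OC(F)(F)F)c(F)c2)CC1`, has not yet been measured in this assay. It differs from compound 1 by the same change: isopropyl in place of cyclopropyl on a carbonyl carbon. The place of the change is described in identical words for both pairs, so it is the same change made on a different core, and it has appeared only twice among these compounds.

For compound 4 the expected step from compound 1, a 1.7-fold higher number from compound 1 to compound 4 (0.22 log units; within the scatter), is smaller than the earlier one. That expectation rests on compound 1 already standing at 715 ug/mL, a very high number in this assay, where further gains tend to be modest, and on the earlier step being seen only once, on a core that is not broken down against this one. Compound 4 is therefore estimated at 1200 ug/mL, with a range from 450 ug/mL to 3200 ug/mL.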

Compound 4, solubility: 33 ug/mL
The estimate for compound 4 lay 36-fold (1.56 log units) above the measured number; measured number outside the range, below it.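

In this assay, isopropyl in place of cyclopropyl on a carbonyl carbon gave a 22-fold lower number from compound 1 to compound 4 (1.34 log units; beyond the scatter), while the same change on the core of compound 2 gave a 13-fold higher number from compound 2 to compound 3 (1.11 log units; beyond the scatter), and both steps are large and beyond the scatter. The change therefore did not carry from one core to the other in either size or direction, so a step seen on one of these cores gave no safe guide to the step on the other. These two pairs show only that the outcome of this change differed between two cores, each tested once, and they establish neither a general rule for the series nor a reason for the reversal, on which no supporting measurement is available.

The compounds shown leave open which of the differences between the two cores goes with the reversal, and a trifluoromethyl group in place of trifluoromethoxy on the core of compound 1 would be one way to begin separating them. They also leave open how other groups on the same carbonyl carbon, such as tert-butyl, a longer chain such as n-propyl, or a dimethylamino group, would behave on each core.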